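The compounds below may be only part of what the source reports. "The series", "measured", "known", "first", "only" and "open" are said of these compounds alone.

Measured compounds and their solubility values:

compound 1, `COc1cc2cc(C(=O)CC(O)CCC3CC[N+](C)(Cc4ccccc4)CC3)sc2cc1OC`, gives 2500 ug/mL
compound 2, `COc1cc2cc(C(=O)CCC3CC[N+](C)(Cc4ccc([N+](=O)[O-])o4)CC3)sc2cc1OC`, gives 600 ug/mL
compound 3, `COc1cc2cc(C(=O)CCc3cc[n+](C)cc3)sc2cc1OC`, gives 3000 ug/mL

All three were tested in a physicochemical assay for solubility; on this read-out higher numbers stand for higher solubility and lower numbers for lower solubility. Compound 3 stands highest of the three numbers. Compound 1 comes nearest, and its number lies within the usual scatter of compound 3, so the two cannot be told apart on this read-out. Compound 2 lies furthest away, with a number beyond the scatter below compound 3, and it is the only one of the three that clearly differs.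

The next compound, compound 4, `COc1cc2cc(C(=O)CCc3cc[n+](CC4CC4)cc3)sc2cc1OC`, is compound 3 with one change: cyclopropyl in place of hydrogen on a saturated chain carbon bound to an aromatic nitrogen. Cut one bond further out, the same difference reads methyl to cyclopropylmethyl. Within the data shown here, no pair of measured compounds differs in just one place, so there is no measured step of this kind to lean on; the expectation rests on the three values alone, and all three sit in a fairly narrow band apart from compound 2.

For this assay the step from compound 3 to compound 4 is expected to be small and downward, a 1.5-fold lower number from compound 3 to compound 4 (0.18 log units; within the scatter), possibly not beyond the scatter. Compound 4 is therefore estimated at 2000 ug/mL, with a likely range from 800 ug/mL to 4000 ug/mL.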

Compound 4, solubility: 15000 ug/mL
For compound 4 the middle estimate is 7.5-fold (0.88 log units) below the measured one; measured number outside the range, above it.
By their numbers in this assay, from the lowest: compound 2; then compounds 1 and 3 (each within the scatter of the next); then compound 4.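

In this assay the saturated chain carbon bound to an aromatic nitrogen turns out to be a place where a single change can move the number: cyclopropyl in place of hydrogen there gives a 5.0-fold higher number from compound 3 to compound 4 (0.70 log units; beyond the scatter) and so clears the usual scatter. This is the only step shown that changes one place alone, so it isolates this position in a way that compounds 1, 2 and 3, which differ from one another in more than one place, could not. Nothing at hand explains the rise, so the step stands as an observation without a stated cause.

A single step with a single group cannot separate the effect of the cyclopropyl ring itself from that of simply adding carbon atoms at this position, and an ethyl group, a longer chain, a phenyl ring or a chain ending in a hydroxyl group on that carbon would help to tell these apart. On these data alone, the step is also known only on compound 3, so whether the same change would act alike on compound 1 or compound 2 remains open.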